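The source may hold more compounds than are shown below. What is called first, only, known or untested is meant among the compounds shown, and "the series" means these compounds.

Of the compounds shown here, two with a shared core have been measured in a physicochemical assay for solubility; a lower number here means a less soluble compound, a higher number a more soluble compound. Compound 1 `CN1CCN(c2cc(C(F)(F)F)ccc2[C@H]2CCOc3cc(S(=O)(=O)Nc4nccs4)ccc32)CC1` carries a 4-methylpiperazin-1-yl group and gives 176000 nM, the higher of the two numbers. Compound 2 `O=S(=O)(Nc1nccs1)c1ccc2c(c1)OCC[C@H]2c1ccc(C(F)(F)F)cc1-c1nccs1` gives 7000 nM, a lower number, and the gap between compound 1 and compound 2 lies beyond the usual scatter of repeated measurements. Among the compounds with values here, no pair of compounds differing in only one place has been measured, so no single step can be read off directly.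

Compound 3 `O=S(=O)(Nc1nccs1)c1ccc2c(c1)OCC[C@@H]2c1ccc(C(F)(F)F)cc1-c1ccc(F)nc1` has not yet been measured. It differs from compound 1 in one place: 6-fluoropyridin-3-yl in place of 4-methylpiperazin-1-yl on an aromatic carbon. The new compound resembles compound 2 more than compound 1, since both compound 2 and compound 3 carry an aromatic ring where compound 1 carries 4-methylpiperazin-1-yl.

On that basis, compound 3 is expected to fall well below compound 1 in this assay, close to compound 2, which gives 7000 nM. The expected step is an 18-fold lower number from compound 1 to compound 3 (1.25 log units; beyond the scatter). The estimate for compound 3 in this assay is 10000 nM, within a range from 3000 nM to 40000 nM.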

Compound 3, solubility: 21000 nM
For compound 3 the middle estimate is 2.1-fold (0.32 log units) below the measured one; the measured number falls inside the stated range.
By their numbers in this assay, from the lowest: compound 2; then compound 3; then compound 1.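

Within the data shown here, this is the first direct reading at this position, an aromatic carbon ortho to a large group and meta to a trifluoromethyl group: in this assay, placing 6-fluoropyridin-3-yl where 4-methylpiperazin-1-yl stood gives an 8.4-fold lower number from compound 1 to compound 3 (0.92 log units; beyond the scatter) and this lies beyond the usual scatter. The two groups hold the same number of heavy atoms and each is a six-membered ring, so the step does not track group size as counted here; it goes with an aromatic ring carrying one hetero atom replacing a non-aromatic ring carrying two. Nothing measured alongside these numbers gives the reason for the step.

On these data alone, it remains open whether the higher number belongs to the piperazine ring itself or would also hold for another non-aromatic ring at this position, such as morpholin-4-yl, or for an open-chain amine such as dimethylamino. As far as these compounds go, the part played by the fluorine also stays open, and plain pyridin-3-yl at this position would separate it from the effect of the ring.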